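From Compound 1 to Compound 4: a Swap on the Amide Nitrogen

The source may report more compounds than this note shows. Statements on the series, on what has been measured and on what is new or still open speak of the compounds shown alone.

Among the compounds with values here, compound 1 `COc1ccc(CNC(=O)c2c(NC(=O)C(F)(F)F)sc3c2CCCCC3)cc1` is one of three compounds measured in an ADME assay on THP-1 cells (Homo sapiens) for cytotoxicity; on this read-out lower numbers stand for higher toxicity in this test and higher numbers for lower toxicity in this test. In this assay compound 1 gives > 50000 nM, which is a limit of the assay rather than a number. Compound 3 `O=C(Nc1ccccc1)c1c(NC(=O)C(F)(F)F)sc2c1CCCCC2` in this assay gives > 50000 nM, again a limit. Compound 2 `COc1ccc(NC(=O)c2c(NC(=O)c3ccccc3)sc3c2CCCCC3)cc1` in this assay gives > 50000 nM, also a limit. Within the data shown here, the only step between two measured compounds that differ in one place, a step that the two limits leave unreadable from compound 1 to compound 3, has no readable size, both of its ends being limits. What the measurements show is the limit of > 50000 nM in this assay, at which 3 of the 3 values shown sit.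

Compound 4 `Cc1ccc(NC(=O)c2c(NC(=O)C(F)(F)F)sc3c2CCCCC3)cc1` is not yet measured. It differs from compound 1 by 4-methylphenyl in place of 4-methoxybenzyl on an amide-type nitrogen. The step from compound 1 to compound 3 bears on this change, as that step too removes the 4-methoxybenzyl group, yet its size is not readable. Among the measured compounds shown here, nothing among the measured compounds points to a step beyond the scatter in this assay in either direction, and the expected outcome is that compound 4 also reports only a limit. Compound 4 is estimated at 50000 nM, within a range from 20000 nM to 120000 nM. The expected step of a number no higher from compound 1 to compound 4 (the limit leaves the size open) is estimated to stay within the scatter.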

Compound 4, half-maximal cytotoxic concentration: > 50000 nM
Compound 4: only a limit was reported; the forecaster's own chance of this, stated with the estimate: 80%; the middle value sits exactly at the limit.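

In this assay compound 4 gives > 50000 nM, a limit of the assay and not a number. Compound 1 and compound 3 also sit only at limits, so neither step to compound 4 can be read. The compounds shown leave open whether any of these changes shifts the read-out at all, for they show only this: the limit of > 50000 nM in this assay, at which 4 of the 4 values shown sit.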